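Diethylamino on the chain of compound 3

The source may report more compounds than this note shows. Statements on the series, on what has been measured and on what is new or still open speak of the compounds shown alone.

For the measured compounds named here, in a functional assay on the whole organism with Mus musculus as the target, in the rotarod test (a higher number here means that more compound is needed for the effect, a lower number that less compound is needed), compound 3 (`CC(=O)NCC(=O)N(C)c1ccc(Cl)cc1C(=O)c1ccccc1Cl`) gives 58 mg/kg, the highest number so far, against compound 1 (`CN(C(=O)CNC(=O)CN)c1ccc([N+](=O)[O-])cc1C(=O)c1ccccc1Cl`) at 10 mg/kg and compound 2 (`CN(C(=O)CNC(=O)CN)c1ccc([N+](=O)[O-])cc1C(=O)c1ccccc1`) at 2.94 mg/kg. Compound 4 (`CCN(CC)CC(=O)NCC(=O)N(C)c1ccc(Cl)cc1C(=O)c1ccccc1Cl`) carries diethylamino in place of hydrogen on a saturated chain carbon bound to a carbonyl carbon. Going by the values given here, no measured step covers this change. Among the compounds with values here, the only step, a 3.4-fold lower number from compound 1 to compound 2 (0.53 log units; beyond the scatter), puts hydrogen in place of chloro on an aromatic carbon and serves merely as a gauge of size. Compound 1 and compound 2 differ from compound 3 in more than one place, so their lower values say little about this chain. A modest move to a lower number is expected in this assay, with the estimated step of a 2.3-fold lower number from compound 3 to compound 4 (0.37 log units; beyond the scatter). For compound 4 the estimated value is 25 mg/kg, with an expected range of 7 mg/kg to 90 mg/kg.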

Compound 4, dose for half-maximal effect: 34 mg/kg
Beside the measured number, compound 4's estimate is 1.4-fold (0.13 log units) below it; measured number inside the range.
By their numbers in this assay, from the lowest: compound 2; then compound 1; then compounds 4 and 3 (each within the scatter of the next).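

In this assay, the step of a 1.7-fold lower number from compound 3 to compound 4 (0.23 log units; within the scatter) shows that this saturated chain carbon bound to a carbonyl carbon takes diethylamino in place of hydrogen, with its 5 heavy atoms, without a change beyond the scatter. For the compounds shown here, this is the first single-place reading on the chain, as the earlier step concerned only an aromatic carbon. No available evidence bears on this result.

On these data alone, whether dimethylamino, piperidino or a carboxylic acid on the same carbon would give a step beyond the scatter remains open. Also open, as far as these compounds go, is whether diethylamino would behave the same way on the core of compound 1.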